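The source may hold more compounds than are shown below. What is called first, only, known or untested is meant among the compounds shown, and "the series" means these compounds.

Measured compounds in this series:
- compound 1 `COc1cnc(-c2ccncc2)c2[nH]cc(C(=O)C(=O)N3CCN(C(=O)c4ccccc4)CC3)c12`: 6000 nM
- compound 3 `COc1cnc(-n2cc(C)cn2)c2[nH]cc(C(=O)C(=O)N3CCN(C(=O)c4ccccc4)CC3)c12`: 243000 nM
- compound 2 `COc1cnc(-c2cnccn2)c2[nH]cc(C(=O)C(=O)N3CCN(C(=O)c4ccccn4)[C@@H](C)C3)c12`: a limit of the assay, >= 267000 nM

In a functional assay on MT2 cells (Homo sapiens) for cytotoxicity, read by XTT assay, with a stated time of 3 days (on this read-out higher numbers stand for lower toxicity in this test and lower numbers for higher toxicity in this test), compound 1 gives 6000 nM, the lowest of the two numbers shown, i.e. the most toxic reading among them. Compound 3 gives 243000 nM. For compound 2 the read-out is a limit and not a number, >= 267000 nM; this is the limit of >= 267000 nM in this assay, at which 1 of the 3 values shown sits. Within the data shown here, the one step between measured compounds is a 41-fold higher number from compound 1 to compound 3 (1.61 log units; beyond the scatter), a change at the same place as the one followed here.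

Compound 4 `CNC(=O)c1ncn(-c2ncc(OC)c3c(C(=O)C(=O)N4CCN(C(=O)c5ccccc5)CC4)c[nH]c23)n1` is not yet measured in this assay. It differs from compound 1 by 3-(methylcarbamoyl)-1H-1,2,4-triazol-1-yl in place of pyridin-4-yl on an aromatic carbon. Among the measured compounds shown here, the step of a 41-fold higher number from compound 1 to compound 3 (1.61 log units; beyond the scatter) is the only measured step that bears on this change, and there too pyridin-4-yl gave way to a five-membered aromatic ring at this carbon. A step in the same direction, toward a higher number, is therefore expected in this assay, though its size is uncertain from a single precedent. Compound 4 is expected to give about 100000 nM, between 20000 nM and 300000 nM, which means an expected 17-fold higher number from compound 1 to compound 4 (1.22 log units; beyond the scatter).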

Compound 4, half-maximal cytotoxic concentration: > 300000 nM
Compound 4: only a limit was reported (the forecaster's own chance of this, stated with the estimate: 30%); middle value at least 3.0-fold (0.47 log units) from the limit.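

In this assay, a second five-membered aromatic ring at this carbon, 3-(methylcarbamoyl)-1H-1,2,4-triazol-1-yl, also departs sharply from pyridin-4-yl, with an at least 50-fold higher number from compound 1 to compound 4 (1.69 log units; beyond the scatter), so the rise seen with 4-methyl-1H-pyrazol-1-yl is not confined to that one group. The two five-membered rings cannot be put in order: an at least 1.2-fold higher number from compound 3 to compound 4 (0.09 log units; that floor lies within the scatter). The reading for compound 4 is a limit of the assay and not a number: the limit of > 300000 nM in this assay, at which 1 of the 4 values shown sits.

The compounds shown leave open whether the ring or the methylcarbamoyl group carries the reading of compound 4, a question that the unsubstituted 1H-1,2,4-triazol-1-yl group would address. Also open, going by these compounds, is whether a phenyl ring or a pyridin-3-yl group at this carbon would read as low as pyridin-4-yl.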